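Cyclohexyl amide in place of 4-chlorophenyl amide

The compounds below may be only part of what the source reports. "The series", "measured", "known", "first", "only" and "open" are said of these compounds alone.

Measured so far:
Compound 1 `COc1ccc(NC(=O)CN(c2cc(Cl)ccc2OC)S(=O)(=O)c2ccccc2)cc1OC`; in a functional assay on SH-SY5Y cells (Homo sapiens), read by MTT assay, with a stated time of 24 h (a lower number here means that less compound is needed, a higher number that more compound is needed for the effect), compound 1 gives > 20000 nM, which is a limit of the assay, not a number.
Compound 2 `COc1ccc(Cl)cc1N(CC(=O)Nc1ccc(C(F)(F)F)cc1)S(=O)(=O)c1ccccc1`; in this assay compound 2 gives 3750 nM.
Compound 3 `COc1ccc(Cl)cc1N(CC(=O)Nc1ccc(Cl)cc1)S(=O)(=O)c1ccccc1`; in this assay compound 3 gives > 20000 nM, again a limit of the assay.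

Compound 3 therefore stands at the limit, where two of the three values sit (the limit of > 20000 nM in this assay, at which 2 of the 3 values shown sit). Only compound 2 carries a number: the step of an at least 5.3-fold lower number from compound 1 to compound 2 (0.72 log units; beyond the scatter) and the step of an at least 5.3-fold higher number from compound 2 to compound 3 (0.72 log units; beyond the scatter) are both beyond the scatter, while the step that the two limits leave unreadable from compound 1 to compound 3 cannot be read because both ends are limits.

Compound 4 `COc1ccc(Cl)cc1N(CC(=O)NC1CCCCC1)S(=O)(=O)c1ccccc1` differs from compound 3 by cyclohexyl in place of 4-chlorophenyl on an amide-type nitrogen. Among the measured compounds shown here, none of the measured steps touches an aryl-to-cycloalkyl exchange on the amide nitrogen; all three vary substituents on an aromatic ring kept in place. For the measured compounds named here, the shared core with two of three aryl amides already reports only a limit in this assay, and the single number seen, for compound 2, is itself far from potent. Going by the values given here, with no bearing step available, the working expectation for compound 4 is no readable change beyond the scatter, a step of a number no higher from compound 3 to compound 4 (the limit leaves the size open), most likely again a limit. The estimated value for compound 4 is 20000 nM, within 6000 nM to 60000 nM.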

Compound 4, half-maximal effective concentration: 17600 nM
Compound 4: middle estimate off by 1.1-fold (0.06 log units), on the high side, and the stated range covers the measured number.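

In this assay cyclohexyl on the amide nitrogen gives a measured number, so this place does not need an aromatic ring for a readable value. Against the two aryl amides that report only a limit, the change gives an at least 1.1-fold lower number from compound 3 to compound 4 (0.05 log units; that floor lies within the scatter) and an at least 1.1-fold lower number from compound 1 to compound 4 (0.05 log units; that floor lies within the scatter), and neither floor shows a change beyond the scatter, while the true size of both steps stays hidden behind the limits: the limit of > 20000 nM in this assay, at which 2 of the 4 values shown sit. Against the one other amide with a number, the change gives a 4.7-fold higher number from compound 2 to compound 4 (0.67 log units; beyond the scatter), so among the groups on this nitrogen that carry a number, 4-(trifluoromethyl)phenyl has the lower value.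

The compounds shown leave open whether the trifluoromethyl group keeps its advantage on a non-aromatic ring, as in 4-(trifluoromethyl)cyclohexyl. They also do not tell whether a smaller ring such as cyclopropyl, or an open chain such as n-hexyl, would give a value different from that of cyclohexyl at this place.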